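Working notes: 2-phenylethenyl replaces 2-chlorophenyl on the core

This account rests on a few compounds, and the source may have more. Where it says the series, first, only, none or still open, it means among the compounds named here.

In a functional assay on SR cells (Homo sapiens) for antiproliferative activity, with a stated time of 48 h (on this read-out higher numbers stand for weaker inhibition of growth and lower numbers for stronger inhibition of growth), compound 1 `Cc1cc(O)c(C2=NN(c3ccc(S(N)(=O)=O)cc3)C(c3ccccc3O)C2)cc1Cl` gives 26700 nM and compound 2 `Cc1cc(O)c(C2=NN(c3ccc(S(N)(=O)=O)cc3)C(c3ccccc3Cl)C2)cc1Cl` gives 100000 nM. Compound 2 stands at the highest of the two numbers, set apart from compound 1 by the step of a 3.7-fold higher number from compound 1 to compound 2 (0.57 log units; beyond the scatter). Compound 3 `Cc1cc(O)c(C2=NN(c3ccc(S(N)(=O)=O)cc3)C(/C=C/c3ccccc3)C2)cc1Cl` differs from compound 2 by 2-phenylethenyl in place of 2-chlorophenyl on a saturated ring carbon. Within the data shown here, the single measured step exchanges a substituent on an aromatic carbon, not the whole group on this saturated ring carbon, so it does not bear on the present change and gives no direction. In this assay compound 3 is expected to give 50000 nM, between 12000 nM and 100000 nM, an expected step of a 2.0-fold lower number from compound 2 to compound 3 (0.30 log units; within the scatter).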

Compound 3, concentration for total growth inhibition: 33800 nM
Compound 3: middle estimate off by 1.5-fold (0.17 log units), on the high side, and the stated range covers the measured number.
By their numbers in this assay, from the lowest: compounds 1 and 3 (each within the scatter of the next); then compound 2.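

At this saturated ring carbon, the number falls by a 3.0-fold lower number from compound 2 to compound 3 (0.47 log units; beyond the scatter) in this assay when 2-phenylethenyl replaces 2-chlorophenyl, so the position accepts a phenyl ring carried on a double bond. The other comparison gives a 1.3-fold higher number from compound 1 to compound 3 (0.10 log units; within the scatter) and does not separate 2-phenylethenyl from 2-hydroxyphenyl. Nothing available explains either step.

The compounds shown leave open whether the double bond itself matters, which 2-phenylethyl at this carbon would test. On these data alone, how an amine or a carboxylic acid on the phenyl ring of this group would read also remains open.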